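This account rests on a few compounds, and the source may have more. Where it says the series, first, only, none or still open, it means among the compounds named here.

Measured so far:
compound 1 `COC(=O)C1=C(C)N=C(C)/C(=C(\O)OC)C1c1ccc(Cl)cc1` — 8130 nM
compound 2 `COC(=O)C1=C(C)N=C(C)/C(=C(\O)OC)C1c1cccc(OC(C)=O)c1` — 6030 nM
compound 3 `COC(=O)C1=C(C)N=C(C)/C(=C(/O)OC)C1c1cccc(Cl)c1` — 15.9 nM

All three were run in a functional assay (muscle tissue) with Cavia porcellus as the target; on this read-out lower numbers stand for an effect already at smaller amounts and higher numbers for an effect only at larger amounts of compound. Compound 2 gives 6030 nM, the second highest of the three numbers. Its nearest neighbour is compound 1 with 8130 nM; this gap lies within the scatter, so no order between compound 1 and compound 2 can be read. Compound 3 gives 15.9 nM, far below compound 2 and beyond the scatter; no single-place step connects compound 3 to either of the others, so only the two values themselves are shown.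

Compound 4 `COC(=O)C1=C(C)N=C(C)/C(=C(\O)OC)C1c1cccc(C(F)(F)F)c1` is not yet measured. Against compound 2 the change is trifluoromethyl in place of acetoxy on an aromatic carbon.

Within the data shown here, no measured step covers this change, so its size in this assay is open. Because compound 3 gives 15.9 nM with a small group at the same ring and compound 2 gives 6030 nM, a move downward, beyond the scatter, seems more likely than none, but the spread is wide. Compound 4 is expected near 400 nM, between 40 nM and 4000 nM. The step from compound 2 to compound 4 is thus estimated at a 15-fold lower number from compound 2 to compound 4 (1.18 log units; beyond the scatter).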

Compound 4, half-maximal effective concentration: 74.1 nM
Estimate against measurement, compound 4: 5.4-fold (0.73 log units) above, within the range that was stated.
By their numbers in this assay, from the lowest: compound 3; then compound 4; then compounds 2 and 1 (each within the scatter of the next).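

In this assay, among these compounds, the exchange of acetoxy for trifluoromethyl on this aromatic carbon, meta to a large group, gives an 81-fold lower number from compound 2 to compound 4 (1.91 log units; beyond the scatter) and is the first change that can be read in one place. The position therefore responds strongly to the group it carries, even though the count of heavy atoms is the same for the group leaving and the group entering. The counts do differ in that acetoxy carries hydrogen-bond acceptors and a double bond outside the aromatic ring while trifluoromethyl carries neither, but nothing measured on these compounds ties the step to any of these differences.

On these data alone, whether the number follows the loss of the acceptors or something else about trifluoromethyl stays open, and a nitrile, a methoxy group, a carboxylic acid or an amine on the same aromatic carbon would separate these readings. Among the compounds shown here, no single-place step joins compound 4 to compound 1 or to compound 3, so how this change relates to their values cannot be read.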